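Isopropoxy in place of dimethylisoxazolyl on the shared core

A few compounds are considered here, and "the series" means these few. Any claim that something is new, unique, unknown or untested is made for them only; others in the source may bear on it.

Two compounds of the series have numbers in an assay on Sf9 cells for inhibition of histone-lysine N-methyltransferase EZH2 variant Y641N (Homo sapiens), read by scintillation counting, with a stated time of 60 min, in the presence of a further agent that is not named here; on this read-out lower numbers stand for stronger inhibition and higher numbers for weaker inhibition. Compound 1 `Cc1cc(C)c(CN2CCc3ccc(O[C@@H]4CCOC4)c(Cl)c3C2=O)c(=O)[nH]1` carries (oxolan-3-yl)oxy on the shared core; in this assay compound 1 gives 110 nM. Compound 2 `Cc1cc(C)c(CN2CCc3ccc(-c4c(C)noc4C)c(Cl)c3C2=O)c(=O)[nH]1` carries 3,5-dimethyl-1,2-oxazol-4-yl at the same place and in this assay compound 2 gives 8.8 nM. The step of a 13-fold lower number from compound 1 to compound 2 (1.10 log units; beyond the scatter) is the only one measured so far, and compound 2 stands as the lowest of the two numbers.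

Compound 3 `Cc1cc(C)c(CN2CCc3ccc(OC(C)C)c(Cl)c3C2=O)c(=O)[nH]1` is not yet measured. Relative to compound 2 the change is isopropoxy in place of 3,5-dimethyl-1,2-oxazol-4-yl on an aromatic carbon. Within the data shown here, the one step that bears on it is the exchange of (oxolan-3-yl)oxy for the five-membered aromatic ring, a 13-fold lower number from compound 1 to compound 2 (1.10 log units; beyond the scatter), which is large. Compound 3 returns to an oxygen-linked group without a ring, so the expectation is a step back in the other direction, of roughly that size, that is an 8.0-fold higher number from compound 2 to compound 3 (0.90 log units; beyond the scatter), though the smaller group may not land exactly where compound 1 does. Compound 3 is therefore estimated at 70 nM in this assay, with a range from 20 nM to 250 nM.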

Compound 3, half-maximal inhibitory concentration: 160 nM
The estimate for compound 3 lay 2.3-fold (0.36 log units) below the measured number, and the stated range covers the measured number.
By their numbers in this assay, from the lowest: compound 2; then compounds 1 and 3 (each within the scatter of the next).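

In this assay, a second oxygen-linked group also stands well away from the 3,5-dimethyl-1,2-oxazol-4-yl group, with an 18-fold higher number from compound 2 to compound 3 (1.26 log units; beyond the scatter) for the exchange to isopropoxy, so the low number of compound 2 is no longer tied to a comparison with (oxolan-3-yl)oxy alone. On the oxygen, the exchange of oxolan-3-yl for isopropyl gives a 1.5-fold higher number from compound 1 to compound 3 (0.16 log units; within the scatter), so the ring of the oxolane and its additional oxygen show no effect beyond the scatter at this position, and across these three compounds only compound 2, with its five-membered aromatic ring on the aromatic carbon, stands apart from the others. Nothing available explains the gap between the two oxygen-linked groups and the 3,5-dimethyl-1,2-oxazol-4-yl group.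

The compounds shown leave open whether the low number of compound 2 belongs to the aromatic ring as such or to its two methyl groups, a question that phenyl or the unsubstituted 1,2-oxazol-4-yl group on the same carbon would address. Also open, going by these compounds, is where an amine such as morpholin-4-yl, or a longer alkoxy chain, would fall relative to these three compounds.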